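The compounds below may be only part of what the source reports. "The series", "measured", "known", "first", "only" and "open" are said of these compounds alone.

Compound 2, `CN1CCN(C(=O)CCCOc2cc(C(=O)N3CCCCc4sccc43)ccc2NC(=O)c2ccccc2-c2ccccc2)CC1`, gives 6 nM in an assay on CHO cells for inhibition of Vasopressin V2 receptor (Homo sapiens), read by radioligand binding (a lower number here means a stronger inhibitor, a higher number a weaker inhibitor), the lowest of the three numbers at hand. Compound 3, `O=C(Nc1ccc(C(=O)N2CCCCc3sccc32)cc1OCCCC(=O)N1CCC(N2CCCCC2)CC1)c1ccccc1-c1ccccc1`, gives 30 nM in this assay, and compound 1, `O=C(Nc1ccc(C(=O)N2CCCN(Cc3ccccc3)c3sccc32)cc1)c1ccccc1-c1ccccc1`, gives 80 nM. For the measured compounds named here, the one step between neighbours that differ in a single place is a 5.0-fold higher number from compound 2 to compound 3 (0.70 log units; beyond the scatter), so swapping the amine ring on that carbonyl already moves the number noticeably.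

Compound 4, `CN1CCCN(CCCOc2cc(C(=O)N3CCCCc4sccc43)ccc2NC(=O)c2ccccc2-c2ccccc2)CC1`, differs from compound 2 in the same region of the molecule: 4-methyl-1,4-diazepan-1-yl in place of (4-methylpiperazin-1-yl)carbonyl on a saturated chain carbon, three bonds along the chain from an oxygen on an aromatic ring. Here the carbonyl is lost altogether and the ring grows by one member, a change no measured pair shows directly. Going by the values given here, the only bearing comes from compound 3, whose step from compound 2 is a 5.0-fold higher number from compound 2 to compound 3 (0.70 log units; beyond the scatter), which says the tail tolerates alteration with a modest cost. The expected step is therefore a modest rise, a 2.5-fold higher number from compound 2 to compound 4 (0.40 log units; beyond the scatter), with wide uncertainty in either direction. Compound 4 is expected to give about 15 nM in this assay, most likely between 4 nM and 60 nM.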

Compound 4, half-maximal inhibitory concentration: 2 nM
The estimate for compound 4 lay 7.5-fold (0.88 log units) above the measured number; the whole stated range lies above it.
By their numbers in this assay, from the lowest: compound 4; then compound 2; then compound 3; then compound 1.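

The tail on this saturated chain does not need its carbonyl to keep a low number: replacing 3-((4-methylpiperazin-1-yl)carbonyl)propyl with 3-(4-methyl-1,4-diazepan-1-yl)propyl gives a 3.0-fold lower number from compound 2 to compound 4 (0.48 log units; beyond the scatter) in this assay. Change at this position can therefore lower the number as well as raise it, whereas a 5.0-fold higher number from compound 2 to compound 3 (0.70 log units; beyond the scatter) had shown only a rise. Nothing at hand explains this difference.

Going by these compounds, the carbonyl leaves and the ring grows from six-membered to seven-membered in the same step, so the share of each remains open; 3-(4-methylpiperazin-1-yl)propyl, which lacks the carbonyl but keeps the six-membered ring, would separate the two. On these data alone, how a longer chain carrying the 4-methyl-1,4-diazepan-1-yl group would read also stays open.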